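The source may hold more compounds than are shown below. What is called first, only, known or untested is meant among the compounds shown, and "the series" means these compounds.

Measured so far, all in a functional assay on the whole organism (aorta) with Rattus norvegicus as the target; a lower number here means a smaller maximal response, a higher number a larger maximal response:

- compound 1 `CC1(C)C=C(n2ccccc2=O)c2cc(S(=O)(=O)N=[N+]=[N-])ccc2O1`: 88.3%
- compound 2 `CC1(C)C=C(n2ccccc2=O)c2cc(S(N)(=O)=O)ccc2O1`: 77.5%
- compound 3 `CC1(C)C=C(n2ccccc2=O)c2cc(S(=O)(=O)Nc3ccc(C#N)cc3)ccc2O1`: 84%

Compound 3 sits second of the three: its gap to compound 1 and its gap to compound 2 both lie within the scatter, so no order among these three is secure. Among the measured compounds shown here, the only step beyond the scatter is a number 10.8 percentage points lower from compound 1 to compound 2 (beyond the scatter); the steps of a number 4.3 percentage points lower from compound 1 to compound 3 (within the scatter) and a number 6.5 percentage points higher from compound 2 to compound 3 (within the scatter) stay within it.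

Compound 4 `CC1(C)C=C(n2ccccc2=O)c2cc(S(=O)(=O)N3CCOCC3)ccc2O1` has not been measured. It differs from compound 3 as follows: morpholin-4-yl in place of (4-cyanophenyl)amino on a sulfonyl sulfur. All three measured steps vary the same position on the sulfonyl sulfur, and they bear on this change; the spread they cover is modest, with one step beyond the scatter and two within it. A further exchange at this position is therefore expected to move the maximal response by at most a small amount, in either direction, most likely within the scatter, as a number 3 percentage points lower from compound 3 to compound 4 (within the scatter).

Compound 4 is accordingly expected to give 81% in this assay, in the range 70% to 92%.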

Compound 4, largest response reached (Emax), in percent of the reference or control that the assay uses: 75.5%
Compound 4: middle estimate off by 5.5 percentage points, on the high side; the range from low to high includes it.
By their numbers in this assay, from the lowest: compounds 4, 2, 3 and 1 (each within the scatter of the next, the first and the last beyond it).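

In this assay, morpholin-4-yl joins amino as a second group on the sulfonyl sulfur that lies beyond the scatter from azido (a number 12.8 percentage points lower from compound 1 to compound 4 (beyond the scatter)). Neither of the other two steps separates the groups: morpholin-4-yl cannot be told from amino (a number 2 percentage points lower from compound 2 to compound 4 (within the scatter)), and exchanging (4-cyanophenyl)amino for this non-aromatic ring gives no secure change (a number 8.5 percentage points lower from compound 3 to compound 4 (within the scatter)), so azido stands apart only from amino and morpholin-4-yl, not from (4-cyanophenyl)amino. No available evidence accounts for these steps.

On these data alone, whether dimethylamino, piperazin-1-yl or a longer chain ending in a carboxylic acid on the sulfonyl sulfur would fall outside the range of these four compounds stays open. Also open, as far as these compounds go, is whether the gap between azido and morpholin-4-yl would persist on a core other than the one shared here.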